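A Methyl Gives Way to Dimethylamino on a Nitro Scaffold

A few compounds are considered here, and "the series" means these few. Any claim that something is new, unique, unknown or untested is made for them only; others in the source may bear on it.

Compound 1 `Cc1ccc(/C=C2\CCC/C(=C\c3ccccc3[N+](=O)[O-])C2=O)cc1` — 6090 nM
Compound 2 `O=C1CCCC/C1=C\c1ccccc1[N+](=O)[O-]` — 36400 nM
Compound 3 `Cc1ccc(/C=C2\CCC/C(=C\c3ccc([N+](=O)[O-])cc3)C2=O)cc1` — 8530 nM

All three were tested in a functional assay on CCRF-CEM cells (Homo sapiens) for cytotoxicity, with a stated time of 72 h; a lower number here means a stronger inhibitor, a higher number a weaker inhibitor. On the three numbers shown, compound 3 lies between the other two. Its nearest neighbour is compound 1, whose value differs from that of compound 3 by less than the usual scatter of such measurements, so the two cannot be told apart. The furthest is compound 2, which shows a higher number than compound 3 by a margin beyond the scatter, making compound 2 the weaker inhibitor of that pair.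

Compound 4 `CN(C)c1ccc(/C=C2\CCC/C(=C\c3ccc([N+](=O)[O-])cc3)C2=O)cc1` has not yet been measured. It differs from compound 3 in one place: dimethylamino in place of methyl on an aromatic carbon. For the measured compounds named here, no pair of measured compounds shows this same change, so there is no measured step to lean on, and the expectation below rests only on the size of the change and the spread of the values already seen.

The expected step in this assay from compound 3 to compound 4, a 1.3-fold lower number from compound 3 to compound 4 (0.12 log units; within the scatter), is small and roughly neutral, not clearly beyond the scatter in either direction. Compound 4 is therefore estimated at 6500 nM, within a range from 2500 nM to 17000 nM.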

Compound 4, half-maximal inhibitory concentration: > 500000 nM
Compound 4: a limit, no number; the forecaster's own chance of this, stated with the estimate: 5%; middle value at least 76-fold (1.88 log units) from the limit.
By their numbers in this assay, from the lowest: compounds 1 and 3 (each within the scatter of the next); then compound 2. At a limit, above all of these: compound 4.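

Swapping methyl for dimethylamino on this aromatic carbon, para to a large group, is far from a neutral edit: an at least 58-fold higher number from compound 3 to compound 4 (1.76 log units; beyond the scatter). Until now, no two measured compounds differed in only one place, so nothing had shown how much this position matters; here, one substituent separates a compound with a measurable value from one without. In this assay, for the compounds shown here, compound 4 stands at > 500000 nM, which is a limit of the assay and not a number, and the only evidence bearing on this result is that limit itself: the limit of > 500000 nM in this assay, at which 1 of the 4 values shown sits.

The compounds shown leave open whether a plain amino group or a methoxy group at the same place would behave more like methyl or more like dimethylamino. Also open, going by these compounds, are whether the same change on compound 1, with its nitro group placed differently, would bring a step of similar size, and why the change has so large an effect, which these data cannot tell.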